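Swapping Methyl for Fluoro on Compound 1

The source may hold more compounds than are shown below. What is called first, only, known or untested is meant among the compounds shown, and "the series" means these compounds.

In a functional assay on LoVo cells (Homo sapiens) for inhibition, read by MTT assay, with a stated time of 48 h (a higher number here means a weaker inhibitor, a lower number a stronger inhibitor), the measured compounds give these values:
Compound 1 `Cc1nc(N(C)c2ccc([Se]C#N)c(C)c2)c2ccccc2n1`: 19 nM
Compound 2 `COc1ccc(N(C)c2nc(C)nc3ccccc23)cc1C(=O)OCCC[Se]C#N`: 854 nM
Compound 3 `COc1ccc(N(C)c2nc(C)nc3ccccc23)cc1C(=O)OCCCC[Se]C#N`: 1080 nM

Compound 1 has the lowest of the three numbers, and both other compounds lie above it by more than the scatter. Compound 4 `Cc1nc(N(C)c2ccc([Se]C#N)c(F)c2)c2ccccc2n1` departs from compound 1 by one change: fluoro in place of methyl on an aromatic carbon. This is fluoro in place of methyl on an aromatic carbon, ortho to a group of 3 heavy atoms and meta to a large group.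

Within the data shown here, no measured step makes this replacement. The only one available, a 1.3-fold higher number from compound 2 to compound 3 (0.10 log units; within the scatter), concerns a saturated chain elsewhere and offers little guidance here. In this assay, then, no step beyond the scatter is expected, with a slight lean towards a higher number, as compound 1 already stands lowest at 19 nM. The expected change is a 1.6-fold higher number from compound 1 to compound 4 (0.20 log units; within the scatter). For compound 4 the estimate is 30 nM, with an expected range from 8 nM to 110 nM.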

Compound 4, half-maximal inhibitory concentration: 13 nM
Compound 4: middle estimate off by 2.3-fold (0.36 log units), on the high side, and the stated range covers the measured number.
By their numbers in this assay, from the lowest: compounds 4 and 1 (each within the scatter of the next); then compounds 2 and 3 (each within the scatter of the next).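

In this assay, the aromatic carbon ortho to a group of 3 heavy atoms and meta to a large group takes fluoro in place of methyl with a 1.5-fold lower number from compound 1 to compound 4 (0.16 log units; within the scatter). Among these compounds, until now this position had been seen only with methyl, so the low number of compound 1 could not be separated from that group; this pair shows that, of these two groups, methyl is not required for a number in that range. No measurement shown here offers an explanation for this result.

As far as these compounds go, it remains open whether a larger group at this carbon, such as methoxy, trifluoromethyl or an amine, would keep the number in this range. The compounds also leave open how hydrogen at this carbon would compare with methyl and fluoro.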